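The source may report more compounds than this note shows. Statements on the series, on what has been measured and on what is new or still open speak of the compounds shown alone.

Of the compounds shown here, three built on closely related cores have been tested, and a fourth is still open. Compound 1 `Cc1nc2ccc(Br)cc2c(=O)n1NCc1nnc(N2C(=O)CSC2c2ccc(N(C)C)cc2)s1`, compound 2 `Cc1nc2ccc(Br)cc2c(=O)n1NCc1nnc(N2C(=O)CSC2c2ccccc2)s1` and compound 3 `Cc1nc2ccccc2c(=O)n1NCc1nnc(N2C(=O)CSC2c2ccccc2)s1` share a common skeleton and differ only at their outer edges. The test used is a functional assay on the whole organism (strain albino) with Rattus norvegicus as the target, in the maximal electroshock model, with a stated time of 1 h, at a dose of 30 mg/kg by the intraperitoneal route; a lower number here means less inhibition, a higher number more inhibition at the dose given (going by the name of the read-out). In this assay compound 1 gives 60%. Compound 2 gives 60%, and compound 3 gives 60%.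

Two single changes connect these three. From compound 2 to compound 1 the change is dimethylamino in place of hydrogen on an aromatic carbon, and the step it produced was no change at the digits printed from compound 2 to compound 1 (within the scatter). From compound 2 to compound 3 the two cores differ by hydrogen in place of bromo on an aromatic carbon, and that step was no change at the digits printed from compound 2 to compound 3 (within the scatter).

Compound 4 `Cc1nc2ccccc2c(=O)n1NCc1nnc(N2C(=O)CSC2c2ccc(N(C)C)cc2)s1` is the unmeasured member. It stands to compound 3 as compound 1 stands to compound 2: the difference is dimethylamino in place of hydrogen on an aromatic carbon, the same change as the one already seen, sitting in the same surroundings on the same kind of ring. Because the earlier instance of this change gave no change at the digits printed from compound 2 to compound 1 (within the scatter), and because the three measured compounds all sit at the same level, the expected step is no change at the digits printed from compound 3 to compound 4 (within the scatter). This expectation rests on a single earlier example of the change and on three measured values that do not separate from one another. Compound 4 is therefore estimated at 60%, with a likely range from 45% to 75%.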

Compound 4, a percentage reported as inhibition, in the whole organism at one dose (the size of the read-out at that dose, not a potency): 60%
Estimate against measurement, compound 4: no gap at the digits printed; measured number inside the range.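

Swapping hydrogen for dimethylamino gives no change at the digits printed from compound 3 to compound 4 (within the scatter) in this assay, and this swap reads the same on the core that carries bromo and on the core that does not: the same change on two cores in this assay, no change at the digits printed (within the scatter) from compound 2 to compound 1 and no change at the digits printed (within the scatter) from compound 3 to compound 4, 0 percentage points apart, within the scatter of two such steps

Swapping bromo for hydrogen gives no change at the digits printed from compound 1 to compound 4 (within the scatter), and this swap reads the same with phenyl and with 4-(dimethylamino)phenyl on the molecule: the same change on two cores in this assay, no change at the digits printed (within the scatter) from compound 2 to compound 3 and no change at the digits printed (within the scatter) from compound 1 to compound 4, 0 percentage points apart, within the scatter of two such steps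

So within these four compounds each change carries from one core to the other, but only in the sense that neither change moves the read-out on either core; this does not show that a change with a real effect would carry over in the same way, and a percentage at a single dose says nothing about potency.

Going by these compounds, it remains open whether other groups in the place of dimethylamino, such as a nitro group or a carboxylic acid, or a longer chain in the place of the methyl group on the shared core, would shift the inhibition at all. On these data alone, it also remains open whether the four compounds would still stay level at another dose or another time point.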